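Solubility across a shared amide series and a heteroaryl swap

This account rests on a few compounds, and the source may have more. Where it says the series, first, only, none or still open, it means among the compounds named here.

The series shares the core seen in compound 1 `Cc1cc(Cl)c(-c2ncc[nH]2)cc1NC(=O)c1ccc(OCc2ccccn2)cc1`, compound 2 `Cc1ccc(-c2cnc(C)n2C)cc1NC(=O)c1ccc(OCc2ccccn2)cc1`, and compound 3 `Cc1cc(C)c(-c2c[nH]nc2C)cc1NC(=O)c1ccc(OCc2ccccn2)cc1`, which differ in the substituents on the aryl ring bearing the amide nitrogen. In a physicochemical assay for solubility, at pH 7.4 (a lower number here means a less soluble compound, a higher number a more soluble compound), compound 2 gives 371000 nM, and compound 3 gives 33000 nM. For compound 1 this assay reports only a limit, < 1000 nM, not a number (the limit of < 1000 nM in this assay, at which 1 of the 3 values shown sits). Among the two numbers shown, compound 3 holds the lower one, with compound 2 sitting higher by a margin beyond the usual scatter.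

Compound 4 `Cc1cc(C)c(-c2ccc(N)nn2)cc1NC(=O)c1ccc(OCc2ccccn2)cc1` has not yet been measured in this assay. It differs from compound 3 in one place: 6-aminopyridazin-3-yl in place of 3-methyl-1H-pyrazol-4-yl on an aromatic carbon. Within the data shown here, no measured pair in this set isolates such a change, so the expectation rests on the spread of the measured values alone. Compound 4 is expected to show a step of a 1.2-fold higher number from compound 3 to compound 4 (0.08 log units; within the scatter) that is modest, plausibly within or slightly above the scatter, in either direction. Compound 4 is therefore estimated at 40000 nM, within a range from 8000 nM to 200000 nM.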

Compound 4, solubility: 6000 nM
Compound 4: middle estimate off by 6.7-fold (0.82 log units), on the high side; the measured number lies below the stated range.
By their numbers in this assay, from the lowest: compound 4; then compound 3; then compound 2. At a limit, below all of these: compound 1.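

Among these compounds, this is the first pair in the set that differs in one place, and it gives this position a measured step: in this assay, 6-aminopyridazin-3-yl in place of 3-methyl-1H-pyrazol-4-yl gives a 5.5-fold lower number from compound 3 to compound 4 (0.74 log units; beyond the scatter) on the shared core. The read-out therefore does not treat these two groups alike on this aromatic carbon, ortho to a methyl group and para to a methyl group, and the lower number comes with a six-membered aromatic ring in place of a five-membered one. Nothing in the data shown accounts for this step.

The ring and its substituents change together in this pair, and one pair cannot separate them. From the compounds shown here alone, whether a 6-methylpyridazin-3-yl group or a pyridazin-3-yl group without the amine would stay near either number remains open.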